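The source may report more compounds than this note shows. Statements on the series, on what has been measured and on what is new or still open speak of the compounds shown alone.

Compound 1 `Oc1cccc(-c2cc(-c3ccoc3)cc(-c3cccc(O)c3)n2)c1` and compound 2 `Oc1ccc(-c2cc(-c3ccoc3)cc(-c3cccc(O)c3)n2)cc1` share a core; in a functional assay on HeLa cells (Homo sapiens) for cytotoxicity, read by CCK-8 assay (on this read-out higher numbers stand for weaker inhibition and lower numbers for stronger inhibition), compound 1 gives 4630 nM, while compound 2 gives 3310 nM, a step of a 1.4-fold lower number from compound 1 to compound 2 (0.15 log units; within the scatter) brought about by 4-hydroxyphenyl in place of 3-hydroxyphenyl on an aromatic carbon. Compound 3 `Oc1ccc(-c2cc(-c3cccnc3)cc(-c3cccc(O)c3)n2)cc1` reaches only a limit of this assay, > 50000 nM. The step of an at least 15-fold higher number from compound 2 to compound 3 (1.17 log units; beyond the scatter) is large, and the difference between the cores of compound 1 and compound 3 is not broken down here. Compound 4 `Oc1ccc(-c2cc(-c3cccnc3)cc(-c3ccc(O)cc3)n2)cc1` arises from compound 3 by 4-hydroxyphenyl in place of 3-hydroxyphenyl on an aromatic carbon, the same kind of change as from compound 1 to compound 2, though here the place is meta to a 4-hydroxyphenyl group and a pyridin-3-yl group. Since that earlier step was within the scatter, compound 4 is expected to stay near the limit of > 50000 nM in this assay, at which 1 of the 3 values shown sits, and to give about 60000 nM, a step that the limit leaves unreadable from compound 3 to compound 4.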

Compound 4, half-maximal inhibitory concentration: 600 nM
Beside the measured number, compound 4's estimate is 100-fold (2.00 log units) above it; the measured number lies below the stated range.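

In this assay, 4-hydroxyphenyl in place of 3-hydroxyphenyl gives an at least 83-fold lower number from compound 3 to compound 4 (1.92 log units; beyond the scatter). The same change therefore does not carry over in size from one core to the other: the same change on two cores in this assay, a 1.4-fold lower number (0.15 log units; within the scatter) from compound 1 to compound 2 and an at least 83-fold lower number (1.92 log units; beyond the scatter) from compound 3 to compound 4, at least 59-fold (1.77 log units) apart, beyond the scatter of two such steps. For compound 3 the value > 50000 nM is a limit and not a number, and these two pairs show only that the outcome of the change differs between the two cores, not why it differs or how it would turn out on any other core.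

The compounds shown leave open what an amine or a methoxy group in place of the hydroxyl on these phenyl groups would do. They also leave open how thiophen-3-yl would behave in place of furan-3-yl or pyridin-3-yl.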